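Chloro Enters the Urea Aryl Ring of Compound 1

A few compounds are considered here, and "the series" means these few. Any claim that something is new, unique, unknown or untested is made for them only; others in the source may bear on it.

Compound 1 `O=C(Nc1cccc(-n2cc(-c3ccncc3)c(-c3ccc(Cl)c(O)c3)n2)c1)Nc1cccc(C(F)(F)F)c1` carries a single trifluoromethyl group on its terminal aryl urea ring. In a functional assay on HCT-116 cells (Homo sapiens) for inhibition, read by sulforhodamine B assay, with a stated time of 48 h (on this read-out higher numbers stand for weaker inhibition of growth and lower numbers for stronger inhibition of growth), compound 1 gives 8260 nM, the higher of the two numbers recorded here. Among the compounds with values here, compound 2 `O=C(Nc1cccc(-n2cc(-c3ccncc3)c(-c3ccc(Cl)c(O)c3)n2)c1)Nc1cc(C(F)(F)F)cc(C(F)(F)F)c1` is its companion, and in this assay compound 2 gives 1110 nM; the step of a 7.4-fold lower number from compound 1 to compound 2 (0.87 log units; beyond the scatter) is the only measured comparison available. Compound 3 `O=C(Nc1cccc(-n2cc(-c3ccncc3)c(-c3ccc(Cl)c(O)c3)n2)c1)Nc1ccc(Cl)c(C(F)(F)F)c1` differs from compound 1 by chloro in place of hydrogen on an aromatic carbon. This change also adds a group to the same aryl ring as the step from compound 1 to compound 2, which lowered the number modestly, so a lowering of similar or somewhat smaller size is expected here, with considerable uncertainty since the entering group is a different one. Compound 3 is therefore estimated to give 2500 nM in this assay, within 1000 nM to 6500 nM, a step of a 3.3-fold lower number from compound 1 to compound 3 (0.52 log units; beyond the scatter).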

Compound 3, concentration for total growth inhibition: 3940 nM
Estimate against measurement, compound 3: 1.6-fold (0.20 log units) below, within the range that was stated.
By their numbers in this assay, from the lowest: compound 2; then compound 3; then compound 1.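

The terminal aryl ring of compound 1 now has a second entry that lowers the number: chloro, on an aromatic carbon ortho to the trifluoromethyl group and para to a large group, gives a 2.1-fold lower number from compound 1 to compound 3 (0.32 log units; beyond the scatter) in this assay. The earlier step, a 7.4-fold lower number from compound 1 to compound 2 (0.87 log units; beyond the scatter), came with a second trifluoromethyl group, so a lower number on this ring is not tied to that one group. Nothing measured here explains why the number falls with either entering group.

From the compounds shown here alone, whether an amine, a methoxy group or a carboxylic acid on this same aromatic carbon would move the number in the same direction remains open. Also open, going by these compounds, is whether chloro would give a similar step on a ring without the trifluoromethyl group.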